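A few compounds are considered here, and "the series" means these few. Any claim that something is new, unique, unknown or untested is made for them only; others in the source may bear on it.

Three compounds that share one core and differ only in the aryl group on an amide-type nitrogen in a ring have been measured in an assay on microsomes from intestine for inhibition of acyl-CoA:cholesterol acyltransferase (Oryctolagus cuniculus); a higher number here means a weaker inhibitor, a lower number a stronger inhibitor. Compound 1 `CCCCCCCC/C=C\CCCCCCCC1=NN(c2c(Cl)cccc2Cl)C(=O)C1` carries a 2,6-dichlorophenyl there and gives 22900 nM. Compound 2 `CCCCCCCC/C=C\CCCCCCCC1=NN(c2ccc(F)cc2F)C(=O)C1` carries a 2,4-difluorophenyl and gives 5000 nM, and compound 3 `CCCCCCCC/C=C\CCCCCCCC1=NN(c2ccc(C)cc2C)C(=O)C1` carries a 2,4-dimethylphenyl and gives 5000 nM. Compound 3 thus stands level with compound 2 at the digits shown, the two together the lowest of the three numbers, while compound 1 lies furthest away, as the step of a 4.6-fold lower number from compound 1 to compound 3 (0.66 log units; beyond the scatter) shows.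

The next compound, compound 4 `CCCCCCCC/C=C\CCCCCCCC1=NN(c2ccc(Cl)cc2Cl)C(=O)C1`, is obtained from compound 3 by the change (2,4-dichlorophenyl in place of 2,4-dimethylphenyl on an amide-type nitrogen in a ring). Two kinds of measured step bear on it. The step of no change at the digits printed from compound 2 to compound 3 (within the scatter) exchanges one 2,4-disubstituted phenyl for another and leaves the number unchanged within the scatter. The steps of a 4.6-fold lower number from compound 1 to compound 2 (0.66 log units; beyond the scatter) and a 4.6-fold lower number from compound 1 to compound 3 (0.66 log units; beyond the scatter) replace the 2,6-dichlorophenyl with a 2,4-disubstituted phenyl and lower the number by a modest amount each time. Compound 4 keeps a 2,4-disubstituted phenyl, so no step beyond the scatter is expected, and the estimated step is no change at the digits printed from compound 3 to compound 4 (within the scatter). Compound 4 is accordingly expected to give about 5000 nM in this assay, within a range from 2000 nM to 13000 nM.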

Compound 4, half-maximal inhibitory concentration: 9900 nM
Compound 4: middle estimate off by 2.0-fold (0.30 log units), on the low side; measured number inside the range.
By their numbers in this assay, from the lowest: compounds 2, 3 and 4 (each within the scatter of the next); then compound 1.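

For the compounds shown here, the 2,4-dichlorophenyl and 2,6-dichlorophenyl groups hold the same atoms and differ only in where the two chlorines sit on the phenyl, so the step of a 2.3-fold lower number from compound 1 to compound 4 (0.36 log units; beyond the scatter) in this assay isolates that arrangement, which the earlier steps from compound 1 had changed together with the kind of substituent. The three 2,4-disubstituted phenyl groups cannot be told apart in this assay, as the steps of a 2.0-fold higher number from compound 3 to compound 4 (0.30 log units; within the scatter) and a 2.0-fold higher number from compound 2 to compound 4 (0.30 log units; within the scatter) show, so at this position on the amide-type nitrogen, chlorine, fluorine and methyl in that arrangement give numbers within the scatter of one another. Nothing available here explains why the arrangement of the chlorines matters.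

On these data alone, it remains open whether a 2,6-dimethylphenyl or a 2,6-difluorophenyl would stand apart from its 2,4-disubstituted partner as the 2,6-dichlorophenyl does. Also open, as far as these compounds go, is what an unsubstituted phenyl, a phenyl bearing an amine or a carboxylic acid, or a shorter chain in place of the long unsaturated one would give on this core.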